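Adding a Cyclopentylcarbamoyl Group to a Weak Kinase Binder

The source may hold more compounds than are shown below. What is called first, only, known or untested is meant among the compounds shown, and "the series" means these compounds.

Compound 1 `CC[C@@H]1C(=O)N(C)c2cnc(-n3ccc4ccccc43)nc2N1C1CCCC1` was tested in an assay for inhibition of serine/threonine-protein kinase PLK3 (Homo sapiens), read by FRET and Z'-LYTE, with a stated time of 1 h; on this read-out higher numbers stand for weaker inhibition and lower numbers for stronger inhibition. In this assay compound 1 gives only a limit of > 20000 nM, not a number. Among the measured compounds shown here, compound 2 `CCC1C(=O)N(C)c2cnc(-n3ccc4cc(F)ccc43)nc2N1c1ccn(C)n1` shares the core of compound 1 and is the only other compound measured here. In this assay compound 2 also gives only a limit of > 10000 nM. Both values shown are thus limits rather than numbers. Compound 1 stands at the limit of > 20000 nM in this assay, at which 1 of the 2 values shown sits. Compound 2 stands at the limit of > 10000 nM in this assay, at which 1 of the 2 values shown sits. For the measured compounds named here, no step between measured compounds can be computed from two limits.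

Compound 3 `CC[C@@H]1C(=O)N(C)c2cnc(-n3ccc4cc(C(=O)NC5CCCC5)ccc43)nc2N1C1CCCC1` has not yet been measured. It differs from compound 1 in one place: cyclopentylcarbamoyl in place of hydrogen on an aromatic carbon. Going by the values given here, with no measured step available, the direction of the change in this assay can only be judged loosely, and no change beyond the usual scatter is assumed. Given that compound 1 sits at a limit, the step from compound 1 to compound 3 is expected to be about an at least 1.3-fold lower number from compound 1 to compound 3 (0.12 log units; that floor lies within the scatter), with wide uncertainty. For compound 3 the estimated value is 15000 nM, within a range from 3000 nM to 60000 nM.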

Compound 3, half-maximal inhibitory concentration: > 20000 nM
Compound 3 gave a limit, no number; the forecaster's own chance of this, stated with the estimate: 60%; middle value at least 1.3-fold (0.12 log units) away from the limit.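

In this assay compound 3 gives > 20000 nM as a limit, not a number. Among the compounds shown here, compound 1 gives a limit too, and no step between compound 1 and compound 3 can be read. From the compounds shown here alone, whether cyclopentylcarbamoyl in place of hydrogen on an aromatic carbon changes inhibition at all stays open. Both compounds share one reading: the limit of > 20000 nM in this assay, at which 2 of the 3 values shown sit.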